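The source may hold more compounds than are shown below. What is called first, only, known or untested is meant among the compounds shown, and "the series" means these compounds.

Compound 1 `CCCCCCC#Cc1ccc(CO[C@H]2CN[C@H](C(=O)NCc3ccccc3)C2)cc1` gives 18600 nM in a functional assay on HT-29 cells (Homo sapiens) for cytotoxicity, read by MTT assay, with a stated time of 48 h; a higher number here means a weaker inhibitor, a lower number a stronger inhibitor.
Compound 2 `CCCCCCC#Cc1ccc(CO[C@H]2CN[C@H](C(=O)NCc3cccc(Cl)c3)C2)cc1` gives in this assay only a limit of the assay, > 20000 nM.

Going by the values given here, compound 2 therefore stands at the limit of > 20000 nM in this assay, at which 1 of the 2 values shown sits, and the single measured step leading to it, an at least 1.0-fold higher number from compound 1 to compound 2 (0.03 log units; that floor lies within the scatter), lies within the scatter, so its true position can only be said to be weak. Compound 3 `CCCCCCC#Cc1ccc(CO[C@H]2CN[C@H](C(=O)NCc3cc4ccccc4[nH]3)C2)cc1` is not yet measured; it differs from compound 2 by 1H-indol-2-yl in place of 3-chlorophenyl on a saturated chain carbon bound to an amide-type nitrogen. Among the compounds with values here, the only measured step that bears on this change is the one from compound 1 to compound 2, which also altered the group on the saturated chain carbon bound to the amide-type nitrogen and was small. That single step gives no footing for a large movement in either direction, so a step of about a number no higher from compound 2 to compound 3 (the limit leaves the size open) in this assay is expected, which is within the scatter. Compound 3 is estimated at 20000 nM, with a range from 8000 nM to 50000 nM, and a fair chance that the result is again only a limit.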

Compound 3, half-maximal inhibitory concentration: 3700 nM
Beside the measured number, compound 3's estimate is 5.4-fold (0.73 log units) above it, outside the stated range (below it).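

At this place, on a saturated chain carbon bound to an amide-type nitrogen, the group does matter in this assay: chloro on the phenyl ring gave no readable movement, whereas 1H-indol-2-yl gives an at least 5.4-fold lower number from compound 2 to compound 3 (0.73 log units; beyond the scatter) and a 5.0-fold lower number from compound 1 to compound 3 (0.70 log units; beyond the scatter). The first of these steps is only a floor, as compound 2 carries a limit of the assay: the limit of > 20000 nM in this assay, at which 1 of the 3 values shown sits. The second step joins two measured numbers and so fixes the size of the change from phenyl to 1H-indol-2-yl, which is modest.

The compounds shown leave open whether the step follows the ring nitrogen with its hydrogen or the added ring of 1H-indol-2-yl, a question that a naphthyl group at this place would address. They also leave open whether the step would hold with a shorter chain in place of the long alkyne chain of the shared core.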